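Chloro for Fluoro, Repeated on a Second Core

The source may report more compounds than this note shows. Statements on the series, on what has been measured and on what is new or still open speak of the compounds shown alone.

Measured so far:
compound 1, `Fc1ccc(/C=N/c2sc3c(c2-c2nc4ccccc4s2)CCC3)cc1`, 372 ug/mL
compound 2, `Clc1ccc(/C=N/c2sc3c(c2-c2nc4ccccc4s2)CCC3)cc1`, 380 ug/mL
compound 3, `Fc1ccc(/C=N/c2sc3c(c2-c2nc4ccccc4s2)CCCC3)cc1`, 277 ug/mL

In an ADME assay on HeLa cells (Homo sapiens) for cytotoxicity, read by MTT assay, with a stated time of 72 h (a higher number here means that more compound is tolerated, a lower number that less compound is tolerated), compound 1 gives 372 ug/mL, and compound 2 gives 380 ug/mL. Between them stands one change, (chloro in place of fluoro on an aromatic carbon), and the result was a 1.0-fold higher number from compound 1 to compound 2 (0.01 log units; within the scatter). Compound 3 sits on a different core; how the two cores differ is not broken down here. In this assay compound 3 gives 277 ug/mL, and its gap to compound 1 and to compound 2 is within the scatter.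

Compound 4, `Clc1ccc(/C=N/c2sc3c(c2-c2nc4ccccc4s2)CCCC3)cc1`, carries the same change on the core of compound 3: chloro in place of fluoro on an aromatic carbon. Because a 1.0-fold higher number from compound 1 to compound 2 (0.01 log units; within the scatter) was within the scatter, the expected step is a 1.0-fold higher number from compound 3 to compound 4 (0.01 log units; within the scatter). Compound 4 is therefore estimated at 285 ug/mL, likely between 160 ug/mL and 500 ug/mL.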

Compound 4, half-maximal cytotoxic concentration: 431 ug/mL
Compound 4: middle estimate off by 1.5-fold (0.18 log units), on the low side; the measured number falls inside the stated range.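

In this assay, chloro in place of fluoro on the core of compound 3 gives a 1.6-fold higher number from compound 3 to compound 4 (0.19 log units; within the scatter), so on this core too the step stays within the scatter. Set beside the step on the core of compound 1, it does not differ: the same change on two cores in this assay, a 1.0-fold higher number (0.01 log units; within the scatter) from compound 1 to compound 2 and a 1.6-fold higher number (0.19 log units; within the scatter) from compound 3 to compound 4, 1.5-fold (0.18 log units) apart, within the scatter of two such steps. This shows that the change carries across these two cores without a detectable difference, but two pairs in one assay do not show that it would hold on any other core, nor do they show a rule for the series.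

On these data alone, it remains open whether a group other than these two halogens, such as a methoxy, an amine or a carboxylic acid, would move the number beyond the scatter. The same question stands for a longer chain in that place.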